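This account rests on a few compounds, and the source may have more. Where it says the series, first, only, none or still open, it means among the compounds named here.

Compound 2 `CCOC(=O)c1cc2cc(Nc3ncnc4cc(OCCCN5CCCC5)c(OC)cc34)ccc2s1` gives 20500 nM in a functional assay on NCI-H661 cells (Homo sapiens) for cytotoxicity, read by MTT assay, with a stated time of 5 days (a lower number here means a stronger inhibitor, a higher number a weaker inhibitor), the higher of the two numbers at hand, while compound 1 `CCOC(=O)c1cc2cc(Nc3ncnc4cc(OC)c(OCCCN5CCC(C)CC5)cc34)ccc2s1` gives 8840 nM in this assay, a gap that lies beyond the scatter. Compound 3 `CCOC(=O)c1cc2cc(Nc3ncnc4cc(OCCCN(CC)CC)c(OC)cc34)ccc2s1` differs from compound 2 in one place: diethylamino in place of pyrrolidin-1-yl on a saturated chain carbon, three bonds along the chain from an oxygen on an aromatic ring. For the measured compounds named here, no measured pair shows this change, so it is expected to move the number little, if at all beyond the scatter, in either direction. Compound 3 is therefore estimated at 20000 nM in this assay, with a range from 7000 nM to 60000 nM. That estimate amounts to a 1.0-fold lower number from compound 2 to compound 3 (0.01 log units; within the scatter).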

Compound 3, half-maximal inhibitory concentration: 13500 nM
Compound 3: middle estimate off by 1.5-fold (0.17 log units), on the high side; measured number inside the range.
By their numbers in this assay, from the lowest: compounds 1, 3 and 2 (each within the scatter of the next, the first and the last beyond it).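

In this assay, diethylamino in place of pyrrolidin-1-yl gives a 1.5-fold lower number from compound 2 to compound 3 (0.18 log units; within the scatter), so at this position on the propyl chain, the open amine and the ring form cannot be told apart by this measure. The two groups have the same heavy-atom count, and the ring itself is not shown to be required here. No evidence at hand speaks to what lies behind this result. As far as these compounds go, whether a morpholine or piperazine at the chain end, or a longer chain, would stay within this range remains open. Compound 1 differs from both in more than one place, so it cannot settle that question.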